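Thromboxane Receptor Antagonists: Pentenyl in Place of Phenethyl

This account rests on a few compounds, and the source may have more. Where it says the series, first, only, none or still open, it means among the compounds named here.

Compound 3 `O=C(O)CCC/C=C\CC1C2CCC(O2)C1CSCCCc1ccccc1` gives 5000 nM in a functional assay on a cell-free system (plasma) for inhibition of thromboxane A2 receptor (Homo sapiens) (on this read-out lower numbers stand for stronger inhibition and higher numbers for weaker inhibition), the larger of the two numbers recorded there, although compound 1 `CCCCCCSC[C@H]1C2CCC(O2)[C@H]1C/C=C\CCCC(=O)O`, at 3800 nM, stands within the usual scatter of it. Compound 2 `CCCCCCSC[C@H]1C2CC[C@@H](O2)[C@H]1C/C=C\CCCC(=O)O` is recorded as 115000 nM; > 1000000 nM; > 1000000 nM (3 entries), several entries taken together. Compound 4 `CCC/C=C\CSCC1C2CCC(O2)C1C/C=C\CCCC(=O)O` remains to be measured; it differs from compound 3 by pent-1-en-1-yl in place of phenethyl on a saturated chain carbon bound to a sulfur. Going by the values given here, no measured pair isolates a change of this kind. Given that compound 1 and compound 3 sit close together on this assay, a step of modest size and uncertain direction is expected, not clearly beyond the scatter. Compound 4 is accordingly estimated at 6000 nM, between 2000 nM and 20000 nM, which amounts to an expected step of a 1.2-fold higher number from compound 3 to compound 4 (0.08 log units; within the scatter).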

Compound 4, half-maximal inhibitory concentration: 5700 nM
Compound 4: the middle estimate sits 1.1-fold (0.02 log units) above what was measured; the measured number falls inside the stated range.
By their numbers in this assay, from the lowest: compounds 1, 3 and 4 (each within the scatter of the next).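

In this assay, the exchange gives a 1.1-fold higher number from compound 3 to compound 4 (0.06 log units; within the scatter), so the six-membered aromatic ring of phenethyl is not required at this place for a number of this size: pent-1-en-1-yl, with no ring and fewer heavy atoms, serves equally on this read-out. Nothing available explains why the exchange leaves the number in place. The compounds shown leave open whether a group bearing an amine on a saturated chain carbon bound to a sulfur would give a clearly different number.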